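Demethylation step transferred to the isomeric benzofuran core

The compounds below may be only part of what the source reports. "The series", "measured", "known", "first", "only" and "open" are said of these compounds alone.

Three compounds are measured in an assay for inhibition of solute carrier family 22 member 12 (Homo sapiens), read by scintillation counting, with a stated time of 60 min, tested at 50 uM; on this read-out higher numbers stand for more inhibition at the one concentration tested (going by the name of the read-out) and lower numbers for less inhibition. Compound 1 `CCc1cc2c(C(=O)c3ccc(OC)cc3)c(OC)ccc2o1` gives 6.1%. Compound 2 `CCc1cc2cc(OC)cc(C(=O)c3ccc(OC)cc3)c2o1` gives 5.2%; the two cores of compound 1 and compound 2 are built from the same atoms joined differently, and the difference between the two cores is not broken down here. Compound 3 `CCc1cc2c(C(=O)c3ccc(OC)cc3)c(O)ccc2o1` gives 28.7%.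

One counted change is present among the measured compounds: hydrogen in place of methyl on an oxygen on an aromatic ring. It made a number 22.6 percentage points higher from compound 1 to compound 3 (beyond the scatter). The values of compound 1 and compound 2 lie within the scatter of each other, so no order between them is read.

Compound 4 `CCc1cc2cc(O)cc(C(=O)c3ccc(OC)cc3)c2o1` is not yet measured. Going by the values given here, its relation to compound 2 is hydrogen in place of methyl on an oxygen on an aromatic ring, which is the same change as the one from compound 1 to compound 3, at the same kind of place. The expectation for compound 4 rests on that single measured step, transferred onto a core that is not the one it was measured on, so the expected step carries added uncertainty. Among the compounds with values here, compound 4 is expected to show a number 16.8 percentage points higher from compound 2 to compound 4 (beyond the scatter), somewhat smaller than the measured step, because a number 22.6 percentage points higher from compound 1 to compound 3 (beyond the scatter) is the only instance and its size on the core of compound 2 is untested. For compound 4 in this assay the estimate is 22%, with an expected range from 6% to 40%.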

Compound 4, a percentage reported as inhibition, at one concentration (the size of the read-out at that concentration, not a potency): 9.3%
Estimate against measurement, compound 4: 12.7 percentage points above; measured number inside the range.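

In this assay, methoxy to hydroxy on the core of compound 2 gives a number 4.1 percentage points higher from compound 2 to compound 4 (within the scatter), so the step measured on the core of compound 1 is not reproduced at its size on this second core: the same change on two cores in this assay, a number 22.6 percentage points higher (beyond the scatter) from compound 1 to compound 3 and a number 4.1 percentage points higher (within the scatter) from compound 2 to compound 4, 18.5 percentage points apart, beyond the scatter of two such steps For these two pairs, the outcome of the change therefore depends on the core that carries it, and a step measured on one core cannot be assumed to hold on the other. This does not show why the two cores behave differently, nor how the change would behave on any further core, since two pairs give only a comparison and no explanation, and each reading is taken at one concentration and says nothing about potency.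

The compounds shown carry only methoxy or hydroxy at the varied place, so it remains open whether a carboxylic acid or an amine there would raise the inhibition on either core. As far as these compounds go, it also remains open whether the difference between the two steps would persist in a full concentration series rather than at the single concentration tested here.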